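The source may report more compounds than this note shows. Statements on the series, on what has been measured and on what is new or still open speak of the compounds shown alone.

Measured compounds:
compound 1 `CC(C)COC(=O)Nc1ccc([Se][Se]c2ccc(NC(=O)OCC(C)C)cc2)cc1`; in a functional assay on CCRF-CEM cells (Homo sapiens) for cytotoxicity, read by MTT assay, with a stated time of 72 h (on this read-out lower numbers stand for stronger inhibition of growth and higher numbers for weaker inhibition of growth), compound 1 gives 39800 nM
compound 2 `N#C[Se]c1ccc(NC(=O)Oc2ccc(F)cc2)cc1`; in this assay compound 2 gives 41900 nM
compound 3 `C=CCOC(=O)Nc1ccc([Se]C#N)cc1`; in this assay compound 3 gives 38100 nM

Compound 3 has the lowest of the three numbers, but its gaps to compound 1 and to compound 2 both lie within the scatter, so no order among the three can be read. Compound 4 `N#C[Se]c1ccc(NC(=O)OCc2ccccc2)cc1` is not yet measured. It differs from compound 3 as follows: phenyl in place of vinyl on a saturated chain carbon bound to an oxygen next to a carbonyl group. The three measured compounds differ widely in structure and still give numbers within the scatter of one another, so this further exchange is expected to move the number little. A step of about a 1.1-fold lower number from compound 3 to compound 4 (0.02 log units; within the scatter) is expected, not beyond the scatter. For compound 4 the estimate in this assay is 36000 nM, with a range from 15000 nM to 85000 nM.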

Compound 4, concentration for total growth inhibition: 48400 nM
Compound 4: middle estimate off by 1.3-fold (0.13 log units), on the low side, within the range that was stated.
By their numbers in this assay, from the lowest: compounds 3, 1, 2 and 4 (each within the scatter of the next).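

At the saturated chain carbon bound to an oxygen next to a carbonyl group, phenyl in place of vinyl gives a 1.3-fold higher number from compound 3 to compound 4 (0.10 log units; within the scatter) in this assay. Among the compounds shown here, this is the first exchange confined to one place, and it shows that a six-membered aromatic ring of carbon only can stand there in place of vinyl without a readable shift in the number. No measured evidence bears on this result. From the compounds shown here alone, whether an amine, a carboxylic acid or a longer chain at this position would give a number beyond the scatter remains open.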